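A few compounds are considered here, and "the series" means these few. Any claim that something is new, unique, unknown or untested is made for them only; others in the source may bear on it.

Three compounds have been measured:
compound 1, `O=C(/C=C/c1ccc(Cl)cc1Cl)c1ccccc1`: 20000 nM 
compound 2, `O=C(/C(=C/C1CCCCC1)CCl)c1ccccc1`: 22000 nM 
compound 3, `CCC(/C=C(\COC(C)=O)C(=O)c1ccccc1)CC`: 52000 nM 

These numbers come from a functional assay on WiDr cells (Homo sapiens) for inhibition, read by sulforhodamine B assay, with a stated time of 48 h; on this read-out higher numbers stand for weaker inhibition of growth and lower numbers for stronger inhibition of growth. Compound 3 stands at the highest of the three numbers, and its distance to compound 2 and to compound 1 lies beyond the usual scatter, so compound 3 inhibits growth more weakly than either. Compound 4, `CC(=O)OC/C(=C\c1ccc(F)cc1)C(=O)c1ccccc1`, has not yet been measured. It differs from compound 3 by 4-fluorophenyl in place of pentan-3-yl on a double-bonded chain carbon bound to a double-bonded chain carbon. For the measured compounds named here, no measured pair shows this change on its own. Compound 1 also carries an aromatic ring on its chain and gives 20000 nM, a lower number than compound 3. A modest step toward stronger inhibition is therefore expected, a 2.1-fold lower number from compound 3 to compound 4 (0.32 log units; beyond the scatter). Compound 4 is estimated at 25000 nM, ranging from 8000 nM to 80000 nM.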

Compound 4, concentration for 50% growth inhibition: 13000 nM
The estimate for compound 4 lay 1.9-fold (0.28 log units) above the measured number, and the stated range covers the measured number.
By their numbers in this assay, from the lowest: compounds 4, 1 and 2 (each within the scatter of the next); then compound 3.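

Changing one place, 4-fluorophenyl in place of pentan-3-yl on a double-bonded chain carbon bound to a double-bonded chain carbon, gives in this assay a 4.0-fold lower number from compound 3 to compound 4 (0.60 log units; beyond the scatter) and so provides the first single-place comparison among these compounds. The step is modest but beyond the scatter, showing that growth inhibition responds to the group at this position. No available evidence explains the change. The compounds shown leave open whether the ring or its fluorine accounts for the step, and how plain phenyl, an amine or a longer chain would behave at this place.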